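This account rests on a few compounds, and the source may have more. Where it says the series, first, only, none or still open, it means among the compounds named here.

In a functional assay on DU-145 cells (Homo sapiens) for antiproliferative activity, read by MTT assay, with a stated time of 48 h (on this read-out higher numbers stand for weaker inhibition and lower numbers for stronger inhibition), the three measured compounds stand as follows.
Compound 1 `C/C(=C\CC/C(C)=C/CC[C@@H]1[C@@]2(C)CCC(=O)C(C)(C)[C@H]2CC[C@@]1(C)O)CC/C=C(\C)C(=O)OCc1cn(-c2ccccc2Br)nn1` gives only a limit of the assay, > 150000 nM.
Compound 2 `C/C(=C\CC/C(C)=C/CC[C@@H]1[C@@]2(C)CCC(=O)C(C)(C)[C@H]2CC[C@@]1(C)O)CC/C=C(\C)C(=O)OCc1cn(-c2cccc(Br)c2)nn1` likewise gives only a limit of the assay, > 150000 nM.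
Compound 3 `C/C(=C\CC/C(C)=C/CC[C@@H]1[C@@]2(C)CCC(=O)C(C)(C)[C@H]2CC[C@@]1(C)O)CC/C=C(\C)C(=O)OCc1cn(-c2ccccc2)nn1` gives 95500 nM.

Compound 3 is thus the only one of the three with a number; the other two values sit at the limit of > 150000 nM in this assay, at which 2 of the 3 values shown sit. The two readable steps both end at compound 3: an at least 1.5-fold lower number from compound 1 to compound 3 (0.19 log units; that floor lies within the scatter) and an at least 1.5-fold lower number from compound 2 to compound 3 (0.19 log units; that floor lies within the scatter), each a change of bromo to hydrogen on the ring attached to the triazole. The step that the two limits leave unreadable from compound 1 to compound 2 cannot be sized at all.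

Compound 4 `C/C(=C\CC/C(C)=C/CC[C@@H]1[C@@]2(C)CCC(=O)C(C)(C)[C@H]2CC[C@@]1(C)O)CC/C=C(\C)C(=O)OCc1cn(-c2cccc(O)c2)nn1` differs from compound 3 by hydroxy in place of hydrogen on an aromatic carbon. Among the compounds with values here, no measured step concerns a hydroxy group, so the bromo steps give only indirect guidance: they show that the ring bearing the triazole tolerates a change in substituent from a limit to a measurable number, but their floor lies within the scatter, so they set no firm direction for a new substituent. The step from compound 3 to compound 4 in this assay is therefore expected to be small, with a 1.0-fold higher number from compound 3 to compound 4 (0.02 log units; within the scatter) judged to lie within the scatter. Compound 4 is accordingly estimated at 100000 nM, with a range from 40000 nM to 250000 nM.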

Compound 4, half-maximal inhibitory concentration: 28400 nM
For compound 4 the middle estimate is 3.5-fold (0.55 log units) above the measured one; the measured number lies below the stated range.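

Against this assay, 3-hydroxyphenyl in place of phenyl gives a 3.4-fold lower number from compound 3 to compound 4 (0.53 log units; beyond the scatter), the first step in this set that is known to lie beyond the scatter. Hydroxy in place of bromo on the same carbon gives an at least 5.2-fold lower number from compound 2 to compound 4 (0.72 log units; beyond the scatter), and 3-hydroxyphenyl in place of 2-bromophenyl gives an at least 5.2-fold lower number from compound 1 to compound 4 (0.72 log units; beyond the scatter), so what enters at this carbon can lower the number, which the earlier compounds could not establish. Both of these steps from the bromo compounds are floors and not full sizes, because those two compounds give only a limit of the assay: the limit of > 150000 nM in this assay, at which 2 of the 4 values shown sit.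

The compounds shown leave open whether the step belongs to this carbon in particular or whether a hydroxy group on another carbon of the ring would give the same result. They also leave open whether a methoxy group, an amine or a carboxylic acid at this carbon would match hydroxy or lower the number further.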